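A few compounds are considered here, and "the series" means these few. Any claim that something is new, unique, unknown or untested is made for them only; others in the source may bear on it.

Measured so far:
compound 1, `S=C(N/N=C/c1ccc2ccccc2n1)Nc1cccc(Br)c1`, 70000 nM in a functional assay on HeLa cells (Homo sapiens) for antiproliferative activity, read by sulforhodamine B assay, with a stated time of 72 h; on this read-out higher numbers stand for weaker inhibition and lower numbers for stronger inhibition
compound 2, `CN(C)C(=S)N/N=C/c1ccc2ccccc2n1`, 90 nM

Compound 2 gives the lowest of the two numbers in this assay; its nearest neighbour is compound 1, whose number is higher by a margin well beyond the scatter. The next compound, compound 3 `S=C(N/N=C/c1ccc2ccccc2n1)Nc1ccccc1`, is not yet measured. It differs from compound 2 in one place: anilino in place of dimethylamino on a thiocarbonyl carbon. Within the data shown here, no step between measured compounds is on record for this kind of change, so the direction can rest only on the two values shown. Among the measured compounds shown here, since compound 1, the only other compound with a thiocarbonyl carbon bearing a substituted nitrogen of this type, gives 70000 nM, the number for compound 3 is expected to rise substantially, by the step of an 89-fold higher number from compound 2 to compound 3 (1.95 log units; beyond the scatter), beyond the scatter. For compound 3 the estimate is 8000 nM, with a likely range from 800 nM to 70000 nM.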

Compound 3, half-maximal inhibitory concentration: 27400 nM
Beside the measured number, compound 3's estimate is 3.4-fold (0.53 log units) below it; the measured number falls inside the stated range.
By their numbers in this assay, from the lowest: compound 2; then compound 3; then compound 1.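

In this assay, among these compounds, the first step on record at this thiocarbonyl carbon, anilino in place of dimethylamino, gives a 300-fold higher number from compound 2 to compound 3 (2.48 log units; beyond the scatter), so the group on this carbon has a large bearing on the read-out. Hydrogen in place of bromo on an aromatic carbon gives a 2.6-fold lower number from compound 1 to compound 3 (0.41 log units; beyond the scatter), a change beyond the scatter but far smaller than the step at the thiocarbonyl carbon. No measurement shown here accounts for either step.

The compounds shown leave open whether the higher number goes with the aromatic ring of anilino or with its hydrogen-bond donor; a methylamino group and a methylanilino group on the thiocarbonyl carbon would separate the two. They also leave open how a methoxy group or a chlorine on the aromatic ring would compare with hydrogen and bromo.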